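The compounds below may be only part of what the source reports. "The series", "measured", "known", "first", "only" and "open" are said of these compounds alone.

Measured so far:
- compound 1 `Cc1n[nH]c2ccc(-c3nc4cnc(N5CCN(C)CC5)cn4c3Nc3ccc(F)cc3)cc12` — "not determined" (no result reported)
- compound 2 `Cc1cc(Br)ccc1Nc1c(-c2ccc3[nH]nc(C)c3c2)nc2cnc(N3CCN(C)CC3)cn12` — "not determined" (no result reported)
- compound 3 `COc1ccc(Nc2c(-c3ccc4[nH]nc(C)c4c3)nc3cnc(N4CCN(C)CC4)cn23)cc1OC` — 0%

In a functional assay on CWR22R cells (Homo sapiens) for inhibition, with a stated time of 120 h, tested at 10 uM (on this read-out higher numbers stand for more inhibition at the one concentration tested (going by the name of the read-out) and lower numbers for less inhibition), compound 1 has no number at all, its entry reading "not determined" (no result reported); its place among the measured compounds is therefore blank. Compound 2 likewise has no number, its entry reading "not determined" (no result reported). Only compound 3 carries a value, and in this assay compound 3 gives 0%, that is, no measurable inhibition at the one concentration tested.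

Compound 4 `Cc1n[nH]c2ccc(-c3nc4cnc(N5CCN(C)CC5)cn4c3Nc3cc(Cl)ccc3Cl)cc12` differs from compound 1 in one place: 2,5-dichlorophenyl in place of 4-fluorophenyl on a nitrogen on an aromatic ring. Among the measured compounds shown here, no pair of measured compounds shows a step in this assay, so the size of this change cannot be read from neighbours. For the measured compounds named here, with the one number pointing to no inhibition, the expected value for compound 4 is estimated at 5%, likely between 0% and 25%.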

Compound 4, a percentage reported as inhibition, at one concentration (the size of the read-out at that concentration, not a potency): 3.8%
The estimate for compound 4 lay 1.2 percentage points above the measured number, within the range that was stated.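

In this assay the change gives a number 3.8 percentage points higher from compound 3 to compound 4 (within the scatter) with 2,5-dichlorophenyl in place of 3,4-dimethoxyphenyl on a nitrogen on an aromatic ring. This second number shows that two differently substituted phenyl groups at this place both leave inhibition close to none, which a single value could not show. Nothing at hand speaks to the reason.

From the compounds shown here alone, whether any group at this place can give clear inhibition remains open. A simple amine or a carboxylic acid on the phenyl ring, or a longer alkyl chain in place of the ring, might read differently.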